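The compounds below may be only part of what the source reports. "The series", "measured", "known", "first", "only" and "open" are said of these compounds alone.

Among the compounds with values here, in a physicochemical assay for lipophilicity, at pH 7.4 (a higher number here means a more lipophilic compound, a lower number a more polar compound), compound 2 `N#Cc1ccccc1C1Cc2nccn2C1` gives 1.3, the lower of the two numbers so far, while compound 1 `FC(F)Oc1ccccc1C1Cc2nccn2C1` gives 2.3. Compound 3 `COc1ccccc1C1Cc2nccn2C1` has methoxy in place of cyano on an aromatic carbon. Within the data shown here, one measured step bears on this: a number 1.00 log units lower from compound 1 to compound 2 (beyond the scatter), a modest change that also involves cyano. It is only a rough guide, as methoxy itself has not been measured. A smaller upward step in this assay is therefore expected, and the expected change is a number 0.50 log units higher from compound 2 to compound 3 (beyond the scatter). For compound 3 the estimate is 1.8, with an expected range of 1.4 to 2.2.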

Compound 3, distribution coefficient: 1.9
Compound 3: middle estimate off by 0.10 log units, on the low side; low and high end bracket the measured number.
By their numbers in this assay, from the lowest: compound 2; then compound 3; then compound 1.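

In this assay, a number 0.60 log units higher from compound 2 to compound 3 (beyond the scatter) shows that this aromatic carbon can carry methoxy with a number that sits apart from the cyano compound. A change on the oxygen alone also counts: a number 0.40 log units lower from compound 1 to compound 3 (beyond the scatter) with methyl in place of difluoromethyl, so the ether pair is separated beyond the scatter. Nothing at hand gives a reason for either step. Still open, on these data alone, are how an amine or a carboxylic acid on this aromatic carbon would read, and whether these steps hold on another core.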